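The source may hold more compounds than are shown below. What is called first, only, known or untested is meant among the compounds shown, and "the series" means these compounds.

Of the compounds shown here, three have so far been measured in a functional assay on HT-29 cells (Homo sapiens) for cytotoxicity, read by MTT assay, with a stated time of 72 h; a lower number here means a stronger inhibitor, a higher number a weaker inhibitor. Compound 1 `CN(C)CCNc1nc(-c2ccc(NC(=O)Nc3ccccc3Cl)cc2)nc2c(Cl)c(Cl)sc12` gives 570 nM, compound 2 `CCN(CC)CCCNc1nc(-c2ccc(NC(=O)Nc3ccccc3Cl)cc2)nc2c(Cl)c(Cl)sc12` gives 410 nM, and compound 3 `CCN(CC)CCNc1nc(-c2ccc(NC(=O)Nc3ccc(Cl)cc3)cc2)nc2c(Cl)c(Cl)sc12` gives 430 nM. Compound 3 thus stands second highest of the three numbers, yet its neighbours sit close on either side: compound 2 is nearest and compound 1 furthest, and both gaps fall within the scatter, so the three compounds cannot be told apart on these numbers.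

Compound 4 `CCN(CC)CCNc1nc(-c2ccc(NC(=O)Nc3ccccc3Cl)cc2)nc2c(Cl)c(Cl)sc12` has not yet been measured. It differs from compound 3 in a single place: 2-chlorophenyl in place of 4-chlorophenyl on an amide-type nitrogen. Going by the values given here, the one measured single step, a 1.4-fold lower number from compound 1 to compound 2 (0.14 log units; within the scatter), concerns the amine end of the chain rather than the chlorophenyl ring, so it does not bear directly on this change, though it does show that an alteration elsewhere left this assay essentially unmoved. Compound 1 already carries the 2-chlorophenyl group together with a different amine, and its value and that of compound 3 lie within the scatter of each other. The change is therefore expected to bring no step beyond the scatter, a 1.1-fold higher number from compound 3 to compound 4 (0.05 log units; within the scatter). Compound 4 is estimated at 480 nM, with a likely range from 250 nM to 950 nM.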

Compound 4, half-maximal inhibitory concentration: 550 nM
Beside the measured number, compound 4's estimate is 1.1-fold (0.06 log units) below it; low and high end bracket the measured number.
By their numbers in this assay, from the lowest: compounds 2, 3, 4 and 1 (each within the scatter of the next).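

In this assay, 2-chlorophenyl in place of 4-chlorophenyl on the amide-type nitrogen gives a 1.3-fold higher number from compound 3 to compound 4 (0.11 log units; within the scatter) and so, with the diethylamino chain held the same, this pair gives the first direct test of where the chlorine sits on this ring, and the two compounds cannot be told apart. Compound 4 also links the amine ends while the 2-chlorophenyl group stays the same: diethylamino in place of (diethylamino)methyl gives a 1.3-fold higher number from compound 2 to compound 4 (0.13 log units; within the scatter) and diethylamino in place of dimethylamino gives a 1.0-fold lower number from compound 1 to compound 4 (0.02 log units; within the scatter) and neither change separates the compounds in this assay. No measurement is available here that could explain why these changes leave the result within the scatter.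

The compounds shown leave open whether the ring on the amide-type nitrogen needs a chlorine at all, since a plain phenyl ring or a methoxyphenyl ring does not appear among them. They also leave open whether a different group at the chain end, such as a morpholine or a carboxylic acid, would move the number beyond the scatter.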